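Swapping the naphthalene for methylphenyl in a cytotoxicity series

A few compounds are considered here, and "the series" means these few. Any claim that something is new, unique, unknown or untested is made for them only; others in the source may bear on it.

Compound 1 `Cc1ccccc1OCc1cn(-c2ccc(S(=O)(=O)N3CCc4ccccc4C3)cc2)nn1`: in an ADME assay on Vero cells (Chlorocebus sabaeus) for cytotoxicity, with a stated time of 4 days (a lower number here means a stronger inhibitor, a higher number a weaker inhibitor), compound 1 gives only a limit, > 50 ug/mL.
Compound 2 `COc1cc2c(cc1OC)CN(S(=O)(=O)c1ccc(-n3cc(COc4ccc([N+](=O)[O-])cc4)nn3)cc1)CC2`: in this assay compound 2 gives only a limit, > 50 ug/mL.
Compound 3 `COc1cc2c(cc1OC)CN(S(=O)(=O)c1ccc(-n3cc(COc4ccc5ccccc5c4)nn3)cc1)CC2`: in this assay compound 3 gives only a limit, > 50 ug/mL.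

Compound 3 therefore stands at a limit, not at a number, and every value shown sits at the same limit (the limit of > 50 ug/mL in this assay, at which 3 of the 3 values shown sit). Among the compounds with values here, the one measured step from a compound that differs in a single place, a step that the two limits leave unreadable from compound 2 to compound 3, cannot be read for size. Compound 4 `COc1cc2c(cc1OC)CN(S(=O)(=O)c1ccc(-n3cc(COc4ccccc4C)nn3)cc1)CC2` is the next compound, with the change (2-methylphenyl in place of naphthalen-2-yl on an oxygen on a saturated carbon). Compound 1 carries the same 2-methylphenyl group and also gives only a limit, so the step that the limit leaves unreadable from compound 3 to compound 4 is expected to be none beyond the scatter. Compound 4 is estimated at 80 ug/mL, within 40 ug/mL to 200 ug/mL.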

Compound 4, half-maximal inhibitory concentration: > 50 ug/mL
Compound 4 ended at the assay's limit (the forecaster's own chance of this, stated with the estimate: 85%); the middle value does not contradict the limit.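

Compound 4, like compound 2 and compound 3, gives only a limit, so the steps among these compounds cannot be read for size. As far as these compounds go, how far each compound lies beyond that limit in this assay remains open.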